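Isopropyl for acetyl on the ring nitrogen: what to expect

A few compounds are considered here, and "the series" means these few. Any claim that something is new, unique, unknown or untested is made for them only; others in the source may bear on it.

The measured compounds:
- compound 1, `Cc1nc2c(OCc3ccc(F)cc3)cccn2c1N`, 95%
- compound 2, `Cc1nc2cc(CCc3ccccc3)ccn2c1N`, 50%
- compound 3, `CC(=O)Nc1c(C)nc2c(OCc3ccccc3)cccn12`, 93%

All three were tested in a functional assay on the whole organism with Rattus norvegicus as the target, at a dose of 40 mg/kg by the intraperitoneal route; on this read-out lower numbers stand for less inhibition and higher numbers for more inhibition at the one dose given (going by the name of the read-out). Compound 3 stands second highest of the three numbers. Its nearest neighbour is compound 1, whose number is within the usual scatter of that of compound 3, so the two cannot be told apart. Its furthest neighbour is compound 2, whose number lies well beyond the scatter below that of compound 3.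

Compound 4, `Cc1nc2c(OCc3ccccc3)cccn2c1NC(C)C`, has not yet been measured in this assay. It differs from compound 3 in one place: isopropyl in place of acetyl on a nitrogen on an aromatic ring. Among the compounds with values here, no pair of measured compounds differs in exactly one place, so the size of such a step has to be guessed. Compound 1 carries a nitrogen with no substituent and gives 95%, while compound 3 carries the acetyl on that nitrogen and gives 93%; both sit high and within scatter of each other, which suggests that what sits on this nitrogen has, so far, changed little. The step from compound 3 to compound 4 is therefore expected to be small, perhaps a modest drop, and possibly none beyond the scatter: a number 8 percentage points lower from compound 3 to compound 4 (within the scatter). Compound 4 is expected to give about 85% in this assay, with a range from 60% to 98%.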

Compound 4, a percentage reported as inhibition, in the whole organism at one dose (the size of the read-out at that dose, not a potency): 18%
Beside the measured number, compound 4's estimate is 67 percentage points above it, and the stated range ends above it.
By their numbers in this assay, from the lowest: compound 4; then compound 2; then compounds 3 and 1 (each within the scatter of the next).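

In this assay, putting isopropyl in place of acetyl on a nitrogen on an aromatic ring gives a number 75 percentage points lower from compound 3 to compound 4 (beyond the scatter), and this single change is the only difference between the two structures, so the group on this nitrogen can matter a great deal in this series. The size of the group, counted in atoms, does not separate the two: acetyl and isopropyl each hold 3 heavy atoms, and what differs is that acetyl brings an oxygen, a double bond and a hydrogen-bond acceptor, while isopropyl has none of these. That count describes the change without explaining the result, and nothing measured here says why the number falls.

The compounds shown cannot tell whether the high number belongs to acetyl in particular or would also be reached with another carbonyl group such as propionyl or benzoyl, or with a methanesulfonyl group. From the compounds shown here alone, it also remains open whether a smaller alkyl group such as methyl or ethyl on this nitrogen would sit nearer compound 3 or compound 4, and where a bare amino group on the core of compound 3 would fall.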